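Halogenated benzyl groups on a nucleoside core

The source may hold more compounds than are shown below. What is called first, only, known or untested is meant among the compounds shown, and "the series" means these compounds.

Compound 1 `OC[C@H]1O[C@@H](n2cnc3c(NCc4ccccc4Br)ncnc32)[C@H](O)[C@@H]1O`: 12300 nM
Compound 2 `COc1cccc(CNc2ncnc3c2ncn3[C@@H]2O[C@H](CO)[C@@H](O)[C@H]2O)c1OC`: > 166000 nM

In a functional assay on CCRF-CEM cells (Homo sapiens) for antiproliferative activity, with a stated time of 72 h (on this read-out higher numbers stand for weaker inhibition and lower numbers for stronger inhibition), compound 2 sits at a limit of the assay, (the limit of > 166000 nM in this assay, at which 1 of the 2 values shown sits), so only a lower bound is known for it. Within the data shown here, the step of an at least 13-fold higher number from compound 1 to compound 2 (1.13 log units; beyond the scatter) is the one measured change here. Compound 3 `OC[C@H]1O[C@@H](n2cnc3c(NCc4ccc(F)cc4Cl)ncnc32)[C@H](O)[C@@H]1O` reverses that kind of change: 2-chloro-4-fluorophenyl in place of 2,3-dimethoxyphenyl on a saturated chain carbon bound to a nitrogen on an aromatic ring. Since compound 1 carries a halogenated phenyl, compound 3 is expected to land near compound 1, a large drop from the limit of compound 2, as an at least 11-fold lower number from compound 2 to compound 3 (1.04 log units; beyond the scatter). The estimate for compound 3 in this assay is 15000 nM, between 4000 nM and 60000 nM.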

Compound 3, half-maximal inhibitory concentration: 20900 nM
Compound 3: middle estimate off by 1.4-fold (0.14 log units), on the low side; low and high end bracket the measured number.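

Placing 2-chloro-4-fluorophenyl where compound 2 carries 2,3-dimethoxyphenyl brings back measurable activity in this assay, with an at least 7.9-fold lower number from compound 2 to compound 3 (0.89 log units; beyond the scatter). That size is only a lower bound, because compound 2 sits at a limit: the limit of > 166000 nM in this assay, at which 1 of the 3 values shown sits. Two differently halogenated phenyl groups now match at this position, with a 1.7-fold higher number from compound 1 to compound 3 (0.23 log units; within the scatter), so bromine is not essential for this level of activity.

From the compounds shown here alone, whether a halogen is needed at all remains open. A plain phenyl, or a phenyl bearing a single methoxy group or an amine, could help separate a benefit from halogens from a penalty from the two methoxy groups.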